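Methoxy to Hydroxy on the Aryl Ring: Expected Effect

The source may report more compounds than this note shows. Statements on the series, on what has been measured and on what is new or still open speak of the compounds shown alone.

Measured so far in an assay on isolated protein for inhibition of Amine oxidase [flavin-containing] B (Homo sapiens), read by spectrophotometry; on this read-out higher numbers stand for weaker inhibition and lower numbers for stronger inhibition:
Compound 1 `COc1ccc(/C=N/Nc2nc3ccccc3nc2Cc2ccccc2)cc1OC` gives 460000 nM.
Compound 2 `COc1ccc(/C(C)=N/Nc2nc3ccccc3nc2Cc2ccccc2)cc1` gives 280000 nM.
Compound 3 `Clc1ccccc1/C=N/Nc1nc2ccccc2nc1Cc1ccccc1` gives 87000 nM.

Compound 2 holds the second highest of the three numbers. Its nearest neighbour is compound 1, whose number lies within the usual scatter of its own, so no order between these two is claimed; compound 3 sits further off, with a number lower by more than the scatter.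

Compound 4 `C/C(=N\Nc1nc2ccccc2nc1Cc1ccccc1)c1ccc(O)cc1` differs from compound 2 in one place: hydrogen in place of methyl on an oxygen on an aromatic ring. For the measured compounds named here, only one measured step touches the aryl ring attached to the carbon with a double bond to nitrogen, namely a 5.3-fold lower number from compound 1 to compound 3 (0.72 log units; beyond the scatter), and that step swaps the whole substitution pattern rather than a single methyl. Going by the values given here, no measured pair isolates a methoxy-to-hydroxy change. The expected step is therefore a 1.4-fold lower number from compound 2 to compound 4 (0.15 log units; within the scatter), a small shift that may not exceed the scatter. Compound 4 is expected to give 200000 nM, within a range from 70000 nM to 600000 nM.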

Compound 4, half-maximal inhibitory concentration: 8400000 nM
Compound 4: middle estimate off by 42-fold (1.62 log units), on the low side, and the stated range ends below it.
By their numbers in this assay, from the lowest: compound 3; then compounds 2 and 1 (each within the scatter of the next); then compound 4.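

In this assay the change from methoxy to hydroxy gives a 30-fold higher number from compound 2 to compound 4 (1.48 log units; beyond the scatter) and is a large step, the first one confined to this oxygen on the aromatic ring. The earlier step on this aryl ring replaced the whole substitution pattern, so it could not show that losing a single methyl here is enough to move the number beyond the scatter. No measurement at hand accounts for the size of this step.

As far as these compounds go, it remains open whether an ethoxy group, a fluorine or an amine in the same place on the ring would give a number close to that of compound 2 or close to that of compound 4. From the compounds shown here alone, it is also open whether the same change would have a similar effect on a compound such as compound 1, which has a hydrogen rather than a methyl on the carbon with a double bond to nitrogen.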